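The source may hold more compounds than are shown below. What is called first, only, known or untested is meant among the compounds shown, and "the series" means these compounds.

Measured so far:
Compound 1 `COc1ccc(/C=C/C(=O)/C=C/c2nc3ccccc3n2C)cc1O`: 6900 nM
Compound 2 `COc1ccc2c(c1)nc(/C=C/C(=O)/C=C/c1ccc(OC)c(O)c1)n2C`: 11700 nM
Compound 3 `COc1ccc(/C=C/C(=O)/C=C/c2nc3cc(Cl)ccc3n2C)cc1O`: 7300 nM

All three values come from a functional assay on NCI-H460 cells (Homo sapiens) for cytotoxicity, read by MTT assay, with a stated time of 48 h; a higher number here means a weaker inhibitor, a lower number a stronger inhibitor. Compound 3 does not stand apart from the other two, and its value lies within the usual scatter of both. The steps that reach it are a 1.1-fold higher number from compound 1 to compound 3 (0.02 log units; within the scatter) and a 1.6-fold lower number from compound 2 to compound 3 (0.20 log units; within the scatter).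

The next compound to be measured is compound 4 `COc1ccc(/C=C/C(=O)/C=C/c2nc3cc([N+](=O)[O-])ccc3n2C)cc1O`. It keeps the core of compound 3 and makes one change, nitro in place of chloro on an aromatic carbon.

Within the data shown here, no measured compound carries nitro, so the evidence is indirect. The closest guide is the set of three swaps already made on an aromatic carbon. Besides the two steps above, there is a 1.7-fold higher number from compound 1 to compound 2 (0.23 log units; within the scatter). None of the three goes beyond the scatter, even though hydrogen, chloro and methoxy are quite different groups. Three compounds are a small sample, however, and nitro could still break this pattern. In this assay, then, no step beyond the scatter is expected, and no direction can be favoured. The expected change is a 1.1-fold lower number from compound 3 to compound 4 (0.05 log units; within the scatter). For compound 4 the estimated value is 6500 nM, with an expected range from 2800 nM to 14000 nM.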

Compound 4, half-maximal inhibitory concentration: 10500 nM
Estimate against measurement, compound 4: 1.6-fold (0.21 log units) below; measured number inside the range.
By their numbers in this assay, from the lowest: compounds 1, 3, 4 and 2 (each within the scatter of the next).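

At this aromatic carbon, nitro brings three heavy atoms and two hydrogen-bond acceptors where chloro had one heavy atom and no acceptor, yet this assay shows only a small step (a 1.4-fold higher number from compound 3 to compound 4 (0.16 log units; within the scatter)). The same holds against the other two groups (a 1.5-fold higher number from compound 1 to compound 4 (0.18 log units; within the scatter); a 1.1-fold lower number from compound 2 to compound 4 (0.05 log units; within the scatter)), so hydrogen, chloro, methoxy and nitro now all sit within the scatter of one another at this position, and none of these four compounds goes against that picture. Nothing measured for these compounds explains why such different groups give such similar numbers.

Among these compounds, whether this position stays as insensitive with an amine, a carboxylic acid or a longer chain remains open, since these four groups are the only ones available for comparison. The rest of the shared core is identical in all four compounds, so they also leave open whether a change elsewhere, such as replacing the hydroxy or methoxy groups on the other aromatic ring, would move the number beyond the scatter.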